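This account rests on a few compounds, and the source may have more. Where it says the series, first, only, none or still open, it means among the compounds named here.

Measured so far in a functional assay on MCF7 cells (Homo sapiens) for cytotoxicity, read by MTT assay, with a stated time of 4 days; on this read-out higher numbers stand for weaker inhibition and lower numbers for stronger inhibition:
- compound 1 `C=C1C(=O)[C@]23C[C@@]1(O)CC[C@H]2c1ccc(O)c(C)c1[C@@H]3Cn1cc(-c2ccccc2)nn1` gives 1740 nM
- compound 2 `C=C1C(=O)[C@]23C[C@@]1(O)CC[C@H]2c1ccc(O)c(C)c1[C@@H]3Cn1cc(-c2ccc(F)cc2)nn1` gives 1700 nM
- compound 3 `C=C1C[C@]23C[C@@]1(O)CC[C@H]2c1cc(Br)c(O)c(C)c1[C@@H]3Cn1cc(-c2ccccc2)nn1` gives only a limit of this assay, > 20000 nM

Compound 2 differs from compound 1 by one change: fluoro in place of hydrogen on an aromatic carbon. The step of a 1.0-fold lower number from compound 1 to compound 2 (0.01 log units; within the scatter). Compound 3 carries a different core; the difference between the two cores is not broken down here. The limit for compound 3 is the limit of > 20000 nM in this assay, at which 1 of the 3 values shown sits, and no number stands behind it.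

Compound 4 `C=C1C[C@]23C[C@@]1(O)CC[C@H]2c1cc(Br)c(O)c(C)c1[C@@H]3Cn1cc(-c2ccc(F)cc2)nn1` has not been measured in this assay. It differs from compound 3 by fluoro in place of hydrogen on an aromatic carbon, the same change as between compound 1 and compound 2. Because a 1.0-fold lower number from compound 1 to compound 2 (0.01 log units; within the scatter), a step of similar size, a step that the limit leaves unreadable from compound 3 to compound 4, is expected here. Compound 4 is therefore expected at 30000 nM, between 15000 nM and 80000 nM, most likely again reported only as a limit.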

Compound 4, half-maximal inhibitory concentration: 19200 nM
Beside the measured number, compound 4's estimate is 1.6-fold (0.19 log units) above it; low and high end bracket the measured number.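

On the core of compound 3, the change phenyl to 4-fluorophenyl in this assay gives an at least 1.0-fold lower number from compound 3 to compound 4 (0.01 log units; that floor lies within the scatter), which is a floor and not a measured size. Compound 3 gives > 20000 nM, which is a limit of the assay and not a number. The step therefore does not show that the change carries over from one core to the other with the same size, nor that it does not: the same change on two cores in this assay, a 1.0-fold lower number (0.01 log units; within the scatter) from compound 1 to compound 2 and an at least 1.0-fold lower number (0.01 log units; that floor lies within the scatter) from compound 3 to compound 4; the limit leaves it open whether they differ

Going by these compounds, a chloro, a methoxy or an amine in place of the fluoro remains open on both cores. Also open, on these data alone, is how a core differing from the core of compound 1 in only one place would behave, and whether the change would then be readable on it.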